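Replacing an amide-bound aryl by a carbamoyl amine

A few compounds are considered here, and "the series" means these few. Any claim that something is new, unique, unknown or untested is made for them only; others in the source may bear on it.

Compound 1 `COc1cc(-c2nn(-c3cccc(NC(=O)c4cccc(C(F)(F)F)c4)c3)cc2-c2ccncc2)ccc1Cl` is assessed in a functional assay on SK-OV-3 cells (Homo sapiens) for inhibition, read by sulforhodamine B assay, with a stated time of 48 h (a lower number here means a stronger inhibitor of growth, a higher number a weaker inhibitor of growth), and its result is a limit of the assay rather than a number: compound 1 gives > 50000 nM. Two further compounds belong to the same study. Compound 2 `O=C(Nc1cccc(-n2cc(-c3ccncc3)c(-c3ccc(Cl)c(O)c3)n2)c1)Nc1cc(C(F)(F)F)cc(C(F)(F)F)c1` gives 3810 nM in this assay, and compound 3 `O=C(Nc1cccc(-n2cc(-c3ccncc3)c(-c3ccc(Cl)c(O)c3)n2)c1)Nc1ccc(Cl)c(C(F)(F)F)c1` gives 14900 nM. Neither compound 2 nor compound 3 differs from compound 1 in a single place, so no step between measured compounds is available; what their values show is that measurable growth inhibition is attainable among these structures, whereas compound 1 sits at the limit (the limit of > 50000 nM in this assay, at which 1 of the 3 values shown sits).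

The unmeasured compound 4 `COc1cc(-c2nn(-c3cccc(NC(=O)Nc4ccc(Cl)c(Cl)c4)c3)cc2-c2ccncc2)ccc1Cl` is reached from compound 1 by one change: (3,4-dichlorophenyl)amino in place of 3-(trifluoromethyl)phenyl on a carbonyl carbon. The same difference, taken one bond further out, reads (3-(trifluoromethyl)phenyl)carbonyl to (3,4-dichlorophenyl)carbamoyl.

In this assay the step is expected to fall in the direction of stronger growth inhibition, estimated as an at least 3.3-fold lower number from compound 1 to compound 4 (0.52 log units; beyond the scatter), because compound 2 gives 3810 nM and compound 3 gives 14900 nM. Compound 1, for its part, reaches only a limit of the assay. Compound 4 is accordingly estimated at 15000 nM, with a plausible range from 4000 nM to 50000 nM, and a fair chance that only a limit is returned.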

Compound 4, concentration for total growth inhibition: > 50000 nM
Compound 4 gave a limit, no number; the forecaster's own chance of this, stated with the estimate: 35%; middle value at least 3.3-fold (0.52 log units) from the limit.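

In this assay compound 4 gives > 50000 nM as a limit of the assay and not a number. Within the data shown here, compound 1 also stands at a limit, so no step from compound 1 to compound 4 can be read. Still open is whether (3,4-dichlorophenyl)amino in place of 3-(trifluoromethyl)phenyl on a carbonyl carbon changes growth inhibition at all, since both compounds sit at the same limit: the limit of > 50000 nM in this assay, at which 2 of the 4 values shown sit.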